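One more hydroxy on compound 3

A few compounds are considered here, and "the series" means these few. Any claim that something is new, unique, unknown or untested is made for them only; others in the source may bear on it.

In a functional assay on MCF7 cells (Homo sapiens) for cytotoxicity, read by MTT assay, with a stated time of 72 h (a higher number here means a weaker inhibitor, a lower number a stronger inhibitor), compound 1 (`COc1cccc(/C=C2\CCC/C(=C\c3ccc(Br)cc3)C2=O)c1OC`) reads 13800 nM and compound 2 (`COc1ccc(/C=C2\CCC/C(=C\c3cccc(OC)c3OC)C2=O)cc1`) reads 18600 nM while compound 3 (`COc1cccc(/C=C2\CCC/C(=C\c3cccc(O)c3)C2=O)c1OC`) reads 8800 nM on the same scale. Compound 3 therefore has the lowest number of the three, though only its gap to compound 2 passes the scatter. Compound 4 (`COc1cccc(/C=C2\CCC/C(=C\c3ccc(O)c(O)c3)C2=O)c1OC`) brings one change (hydroxy in place of hydrogen on an aromatic carbon): hydroxy in place of hydrogen on an aromatic carbon, which turns 3-hydroxyphenyl to 3,4-dihydroxyphenyl. Among the compounds with values here, no measured step makes this exact change. The closest are the ring swaps that lead to compound 3 (a 1.6-fold lower number from compound 1 to compound 3 (0.20 log units; within the scatter); a 2.1-fold lower number from compound 2 to compound 3 (0.33 log units; beyond the scatter)), and both are small. A similarly small drop is expected in this assay here, with the estimated step (a 1.4-fold lower number from compound 3 to compound 4 (0.13 log units; within the scatter)) staying within the scatter. The expected value for compound 4 is 6500 nM (range 2500 nM to 15000 nM).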

Compound 4, half-maximal inhibitory concentration: 4700 nM
Beside the measured number, compound 4's estimate is 1.4-fold (0.14 log units) above it, and the stated range covers the measured number.
By their numbers in this assay, from the lowest: compounds 4, 3, 1 and 2 (each within the scatter of the next, the first and the last beyond it).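

Placing a hydroxy on the aromatic carbon ortho to the existing hydroxy gives a 1.9-fold lower number from compound 3 to compound 4 (0.27 log units; within the scatter) and so, taken alone, this addition cannot be told apart from the scatter. Even so, the 3,4-dihydroxyphenyl ring stands clear of the 4-bromophenyl ring (a 2.9-fold lower number from compound 1 to compound 4 (0.47 log units; beyond the scatter)), a gap the 3-hydroxyphenyl ring did not reach, and of the 4-methoxyphenyl ring (a 4.0-fold lower number from compound 2 to compound 4 (0.60 log units; beyond the scatter)). No measurement shown gives a reason for these steps.

The compounds shown leave open whether the hydroxy itself matters at this position. An amine or a carboxylic acid on the same aromatic carbon could test that.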